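The source may hold more compounds than are shown below. What is called first, only, known or untested is meant among the compounds shown, and "the series" means these compounds.

Three compounds share one core and differ only in the group carried on an amine nitrogen in a ring. Compound 1 `CCCn1c(=O)[nH]c2nc(-c3ccc(S(=O)(=O)N4CCN(c5ccc(F)cc5)CC4)cc3)[nH]c2c1=O` carries a 4-fluorophenyl there, and in an assay on CHO cells for displacement of a labelled ligand from adenosine receptor A2b (Homo sapiens), read by scintillation counting, with a stated time of 75 min, in the presence of a further agent that is not named here (a lower number here means a stronger inhibitor, a higher number a weaker inhibitor), compound 1 gives 0.644 nM. Compound 2 `CCCn1c(=O)[nH]c2nc(-c3ccc(S(=O)(=O)N4CCN(Cc5cccc(C)c5)CC4)cc3)[nH]c2c1=O` carries a 3-methylbenzyl, and in this assay compound 2 gives 0.397 nM. Compound 3 `CCCn1c(=O)[nH]c2nc(-c3ccc(S(=O)(=O)N4CCN(Cc5ccc(Br)c(F)c5)CC4)cc3)[nH]c2c1=O` carries a 4-bromo-3-fluorobenzyl, and in this assay compound 3 gives 0.473 nM. Compound 3 stands second highest of the three numbers, but every step among them lies within the usual scatter: a 1.4-fold lower number from compound 1 to compound 3 (0.13 log units; within the scatter), a 1.2-fold higher number from compound 2 to compound 3 (0.08 log units; within the scatter), and a 1.6-fold lower number from compound 1 to compound 2 (0.21 log units; within the scatter). Compound 4 `CCCn1c(=O)[nH]c2nc(-c3ccc(S(=O)(=O)N4CCN(c5ccccc5Cl)CC4)cc3)[nH]c2c1=O` is the next step: 2-chlorophenyl in place of 4-bromo-3-fluorobenzyl on an amine nitrogen in a ring. The earlier swap of a directly attached ring for a benzyl on this nitrogen, from compound 1 to compound 3, was small, and the change of halogens and methyl on the ring from compound 2 to compound 3 was small too. Compound 4 is therefore expected to show no step beyond the scatter, a 1.2-fold higher number from compound 3 to compound 4 (0.07 log units; within the scatter). The estimate for compound 4 in this assay is 0.55 nM, in a range from 0.25 nM to 1.3 nM.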

Compound 4, inhibition constant: 0.403 nM
Beside the measured number, compound 4's estimate is 1.4-fold (0.14 log units) above it; the measured number falls inside the stated range.
By their numbers in this assay, from the lowest: compounds 2, 4, 3 and 1 (each within the scatter of the next).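

The 2-chlorophenyl group on this amine nitrogen gives no step beyond the scatter from any earlier group: a 1.2-fold lower number from compound 3 to compound 4 (0.07 log units; within the scatter), a 1.0-fold higher number from compound 2 to compound 4 (0.01 log units; within the scatter) and a 1.6-fold lower number from compound 1 to compound 4 (0.20 log units; within the scatter). This adds a second directly attached ring with a different halogen at a different ring position, and in this assay all four compounds remain within the scatter of one another, whether the ring is attached directly or as a benzyl. No other measurement is available to explain this lack of separation.

Going by these compounds, all four groups contain a carbon-only aromatic ring, so it remains open whether the number would hold with a pyridine ring, a carboxylic acid or a plain alkyl chain on this nitrogen. These results also cannot show whether other adenosine receptors would separate these four groups.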